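The source may hold more compounds than are shown below. What is called first, only, known or untested is meant among the compounds shown, and "the series" means these compounds.

Working notes on the series. For the measured compounds named here, compound 1 `Cc1c(C(=O)NCc2cccc(C(F)(F)F)c2)cnn1-c1ccc(Cl)c(Cl)c1` is the only member with a numeric value in a functional assay on cells for antagonist activity at C-C chemokine receptor type 1 (Homo sapiens), read by FLIPR and calcium flux; on this read-out higher numbers stand for weaker inhibition and lower numbers for stronger inhibition: compound 1 gives 500 nM. Compound 2 `Cc1c(C(=O)NCc2cccc(C(F)(F)F)c2)cnn1-c1cccc(C(F)(F)F)c1` returns only a limit of the assay in this assay, > 3000 nM. Compound 3 `O=C(NCc1cccc(C(F)(F)F)c1)c1cnn(-c2ccc(Cl)c(Cl)c2)c1` likewise returns only a limit in this assay, > 3000 nM. Both measured steps out of compound 1 therefore run into (the limit of > 3000 nM in this assay, at which 2 of the 3 values shown sit). Exchanging the aryl on the aromatic nitrogen costs an at least 6.0-fold higher number from compound 1 to compound 2 (0.77 log units; beyond the scatter); stripping the methyl from the core costs an at least 6.0-fold higher number from compound 1 to compound 3 (0.77 log units; beyond the scatter).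

Compound 4 `Cc1nn(-c2ccc(Cl)c(Cl)c2)c(C)c1C(=O)NCc1cccc(C(F)(F)F)c1` differs from compound 1 in one place: methyl in place of hydrogen on an aromatic carbon. The new methyl sits next to the ring nitrogen and next to the ring atom that bears a large group. Going by the values given here, the only measured step that bears on it is the methyl step, an at least 6.0-fold higher number from compound 1 to compound 3 (0.77 log units; beyond the scatter), which shows the first methyl on the core contributes to inhibition. Among the compounds with values here, no measured pair shows what a second methyl on the core does, so the expectation stays close to compound 1 with a wide spread. Compound 4 is expected to give 600 nM in this assay, between 150 nM and 3000 nM, an estimated step of a 1.2-fold higher number from compound 1 to compound 4 (0.08 log units; within the scatter) that is not expected to exceed the scatter.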

Compound 4, half-maximal inhibitory concentration: > 3000 nM
Compound 4: only a limit was reported; the forecaster's own chance of this, stated with the estimate: 25%; at least 5.0-fold (0.69 log units) between middle value and limit.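

In this assay methyl in place of hydrogen on the aromatic carbon next to the ring nitrogen gives an at least 6.0-fold higher number from compound 1 to compound 4 (0.77 log units; beyond the scatter) and so lies beyond the scatter; this position of the core of compound 1 now has a reading of its own, and the change is not neutral there. The value of compound 4, > 3000 nM in this assay, is a limit of the assay and not a number. Read together with an at least 6.0-fold higher number from compound 1 to compound 3 (0.77 log units; beyond the scatter) on the other side of compound 1, the new step shows that both the loss of the existing methyl and the gain of a second methyl weaken inhibition, so more methyl on the core does not simply go with stronger inhibition, though the true size of neither step can be read: the limit of > 3000 nM in this assay, at which 3 of the 4 values shown sit.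

The compounds shown leave open whether this carbon accepts anything other than hydrogen, for instance a fluorine atom, an amine or a longer chain such as ethyl. They also leave open whether the loss from the second methyl holds with an aryl other than 3,4-dichlorophenyl on the ring nitrogen, or with another group in place of the 3-(trifluoromethyl)benzyl amide.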